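The compounds below may be only part of what the source reports. "The series", "measured", "known", "first", "only" and "open" are said of these compounds alone.

Measured so far:
- compound 1 `COc1cc(-c2nnc(SCc3ccc([N+](=O)[O-])cc3)o2)ccc1O`; in a functional assay on cells (T-cell, Mus musculus, strain BALB/c) for inhibition, read by MTT assay, with stated times of 24 h and 72 h (a lower number here means a stronger inhibitor, a higher number a weaker inhibitor), compound 1 gives 14200 nM
- compound 2 `COc1cc(-c2nnc(SCc3cccc(Br)c3)o2)ccc1O`; in this assay compound 2 gives 48100 nM
- compound 3 `COc1cc(-c2nnc(SCc3ccc(Cl)cc3)o2)ccc1O`; in this assay compound 3 gives 11100 nM

Compound 1 stands second highest of the three numbers. Its nearest neighbour is compound 3, reached by a 1.3-fold lower number from compound 1 to compound 3 (0.11 log units; within the scatter), so the two cannot be ordered. For the measured compounds named here, compound 2 gives the highest number of the three, and the gap from compound 1 to compound 2 is beyond the scatter; the one step involving compound 2 that is recorded, a 4.3-fold lower number from compound 2 to compound 3 (0.64 log units; beyond the scatter), concerns a different change of the benzyl ring.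

Compound 4 `COc1cc(-c2nnc(SCc3ccc(F)cc3)o2)ccc1O` has not yet been measured. It differs from compound 1 in one place: fluoro in place of nitro on an aromatic carbon. The step that bears directly on this change is a 1.3-fold lower number from compound 1 to compound 3 (0.11 log units; within the scatter), where a halogen likewise replaces the nitro group on the same aromatic carbon and the number barely moves. On that basis the expected change from compound 1 to compound 4 is a 1.1-fold lower number from compound 1 to compound 4 (0.04 log units; within the scatter), that is, no step beyond the scatter in either direction. Compound 4 is therefore estimated at 13000 nM, with a range from 6000 nM to 30000 nM.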

Compound 4, half-maximal inhibitory concentration: 8190 nM
Estimate against measurement, compound 4: 1.6-fold (0.20 log units) above; the measured number falls inside the stated range.
By their numbers in this assay, from the lowest: compounds 4, 3 and 1 (each within the scatter of the next); then compound 2.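

In this assay the aromatic carbon para to a large group now carries three groups that cannot be ordered: fluoro in place of nitro gives a 1.7-fold lower number from compound 1 to compound 4 (0.24 log units; within the scatter) and fluoro in place of chloro gives a 1.4-fold lower number from compound 3 to compound 4 (0.13 log units; within the scatter) so nitro, chloro and fluoro are not told apart here. Nitro brings three heavy atoms and two hydrogen-bond acceptors where fluoro brings one heavy atom and none, and that difference leaves the number within the scatter. The comparison with the 3-bromophenyl compound recurs with fluoro as a 5.9-fold lower number from compound 2 to compound 4 (0.77 log units; beyond the scatter) and, like the step to compound 3, it changes both the halogen and its place on the ring, so neither change can be singled out.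

From the compounds shown here alone, whether an amine, a carboxylic acid or a longer chain on this carbon would move the number beyond the scatter stays open. Nothing measured here bears on the reasons for these steps.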